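The source may report more compounds than this note shows. Statements on the series, on what has been measured and on what is new or still open speak of the compounds shown alone.

Measured so far:
- Compound 1 `O=C(Nc1cc(-c2ccccc2)nn1-c1ccccc1)c1ccc([N+](=O)[O-])cc1`: 10.7 nM
- Compound 2 `O=C(Nc1cc(-c2ccccc2)nn1-c1ccccc1Br)c1ccccc1`: 200 nM

In a functional assay on cells for positive allosteric modulation of metabotropic glutamate receptor 5 (Rattus norvegicus), read by calcium flux (a lower number here means that less compound is needed, a higher number that more compound is needed for the effect), compound 1 gives 10.7 nM, and compound 2 gives 200 nM. Of the two numbers, compound 2 has the higher one; the nearest number, that of compound 1, lies well beyond the usual scatter below it. Compound 1 and compound 2 differ in more than one place. For the measured compounds named here, no single step between them can be read from these two values.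

Compound 3 `O=C(Nc1cc(-c2ccccc2)nn1-c1ccccc1Br)c1ccc([N+](=O)[O-])cc1` has not yet been measured. It differs from compound 2 in one place: nitro in place of hydrogen on an aromatic carbon, the nitro sitting para to a large group on a six-membered aromatic ring of carbon only, so that the phenyl becomes a 4-nitrophenyl. Compound 1 carries this same nitro group and shows the lower number, so the nitro is expected to move compound 3 toward a lower number in this assay, by a step that is expected to be beyond the scatter: a 5.0-fold lower number from compound 2 to compound 3 (0.70 log units; beyond the scatter). The expected value for compound 3 in this assay is 40 nM, with a range from 8 nM to 200 nM.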

Compound 3, half-maximal effective concentration: 61 nM
Estimate against measurement, compound 3: 1.5-fold (0.18 log units) below, within the range that was stated.
By their numbers in this assay, from the lowest: compound 1; then compound 3; then compound 2.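

In this assay, nitro in place of hydrogen on the phenyl gives a 3.3-fold lower number from compound 2 to compound 3 (0.52 log units; beyond the scatter), so the 4-nitrophenyl goes with a lower number even when the bromo group is present. Bromo in place of hydrogen, with the nitro group held fixed, gives a 5.7-fold higher number from compound 1 to compound 3 (0.76 log units; beyond the scatter), which shows that the bromo group goes with a higher number when the rest of the compound stays the same. Compound 1 and compound 2 differ in two places, and these two steps now let each change be read on its own, in opposite directions and both beyond the usual scatter, although nothing measured here explains the size or direction of either step.

For the compounds shown here, the nitro step and the bromo step have each been read on only one pair of compounds, so neither can yet be taken as a general pattern. Going by these compounds, it also remains open whether a nitrile or a methoxy group in place of the nitro, or a chloro or a fluoro group in place of the bromo, would give steps of similar size and direction.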